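The compounds below may be only part of what the source reports. "The series", "measured", "known", "first", "only" and "open" are said of these compounds alone.

Compound 1 `Cc1n[nH]c(N)c1-c1ccc(Cl)cc1` was tested in an assay on Sf9 cells for inhibition of inhibitor of nuclear factor kappa-B kinase subunit epsilon (Homo sapiens), read by ADP-Glo, with a stated time of 60 min; on this read-out lower numbers stand for stronger inhibition and higher numbers for weaker inhibition. In that assay compound 1 gives > 100000 nM, which is a limit of the assay and not a number. Two related compounds were measured beside it. Compound 2 `CCC(=O)n1nc(C)c(-c2ccc(Cl)c(Cl)c2)c1N` gives > 100000 nM, likewise a limit. Compound 3 `Cc1nn(C(=O)C2CCCC2)c(N)c1-c1ccc(Cl)c(Cl)c1` gives > 100000 nM, again a limit. The step that the two limits leave unreadable from compound 2 to compound 3 therefore cannot be read, because of the limit of > 100000 nM in this assay, at which 3 of the 3 values shown sit. Compound 4 `CC(=O)n1nc(C)c(-c2ccc(Cl)cc2)c1N` differs from compound 1 by acetyl in place of hydrogen on an aromatic nitrogen. Within the data shown here, no measured step bears directly on this change, and all three values sit at the same limit, so no step beyond the scatter can be foreseen in this assay. Compound 4 is expected to give 150000 nM, between 50000 nM and 500000 nM, most probably again as a limit. That estimate corresponds to an expected step that the limit leaves unreadable from compound 1 to compound 4.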

Compound 4, half-maximal inhibitory concentration: > 100000 nM
Compound 4 was reported as a limit (the forecaster's own chance of this, stated with the estimate: 90%); the middle value lies beyond the limit too.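

No step can be read between compound 1 and compound 4, as both are reported only as a limit: the limit of > 100000 nM in this assay, at which 4 of the 4 values shown sit. The compounds shown leave open which change to the shared core, if any, would give a measurable value in this assay.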